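Trifluoromethyl to methoxy: an expectation for compound 4

The compounds below may be only part of what the source reports. "The series", "measured", "known", "first", "only" and "open" are said of these compounds alone.

Compound 1 `Nc1nsc(-c2ccc(N3CCN(c4cccc(C(F)(F)F)c4)CC3)nn2)n1` gives 20 nM
Compound 2 `CN(C)c1nsc(-c2ccc(N3CCN(c4cccc(C(F)(F)F)c4)CC3)nn2)n1` gives 6 nM; 0.4 nM (2 entries)
Compound 3 `Cc1nsc(-c2ccc(N3CCN(c4cccc(C(F)(F)F)c4)CC3)nn2)n1` gives 0.3 nM

In a functional assay (aorta) for inhibition, with Rattus norvegicus as the target, with a stated time of 8 days (on this read-out higher numbers stand for weaker inhibition and lower numbers for stronger inhibition), compound 3 holds the lower of the two single numbers, and the gap is a 67-fold lower number from compound 1 to compound 3 (1.82 log units; beyond the scatter) in its favour. Compound 2 has no single number (the several entries of compound 2 in this assay, 6 nM; 0.4 nM (2 entries)). Compound 4 `COc1cccc(N2CCN(c3ccc(-c4nc(C)ns4)nn3)CC2)c1` differs from compound 3 by methoxy in place of trifluoromethyl on an aromatic carbon on an aromatic carbon. Among the measured compounds shown here, the only measured step, a 67-fold lower number from compound 1 to compound 3 (1.82 log units; beyond the scatter), concerns a different group, so it shows how far numbers can move in this assay but gives no direction for this change. For the measured compounds named here, no measured compound alters the trifluoromethyl. With compound 3 at 0.3 nM as the starting point, an expected 6.7-fold higher number from compound 3 to compound 4 (0.82 log units; beyond the scatter) points modestly toward weaker inhibition, with a wide margin. Compound 4 is estimated at 2 nM (0.2 nM to 20 nM) in this assay on this reasoning.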

Compound 4, half-maximal inhibitory concentration: 7 nM
The estimate for compound 4 lay 3.5-fold (0.54 log units) below the measured number; the range from low to high includes it.
By their numbers in this assay, from the lowest: compound 3; then compound 4; then compound 1.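

In this assay the change of methoxy in place of trifluoromethyl gives a 23-fold higher number from compound 3 to compound 4 (1.37 log units; beyond the scatter) and thus a large step toward weaker inhibition. Among the compounds shown here, this is the first measured sign that this place, on an aromatic carbon meta to a large group, is sensitive to the group it carries, and here trifluoromethyl gives the lower number. Nothing at hand bears on the cause of this step.

The compounds shown leave open how a chlorine, a nitrile or an amine at this place would compare. They also leave open whether the same change would give a step of similar size with the amino group of compound 1 in place of the methyl.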